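Ring-nitrogen substituent: step from compound 3 to compound 4

This account rests on a few compounds, and the source may have more. Where it says the series, first, only, none or still open, it means among the compounds named here.

Measured so far:
compound 1, `CCCCn1cnc2c(NCc3ccc(C(=O)Nc4ccccc4N)cc3)nc(Cl)nc21`: in a functional assay on HepG2 cells (Homo sapiens) for antiproliferative activity, read by CCK-8 assay, with a stated time of 72 h, tested at 2 uM (on this read-out higher numbers stand for a stronger effect at the one concentration tested and lower numbers for a weaker effect), compound 1 gives 6.8%
compound 2, `Nc1ccccc1NC(=O)/C=C/c1ccc(COCNc2nc(Nc3cccc(Cl)c3)c3ncn(C4CCCC4)c3n2)cc1`: in this assay compound 2 gives 9.67%
compound 3, `CC(C)n1cnc2c(NCc3ccc(C(=O)Nc4ccccc4N)cc3)nc(Cl)nc21`: in this assay compound 3 gives 63.8%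

Compound 3 stands highest of the three numbers in this assay. The nearest is compound 2, whose number is lower by more than the scatter; the furthest is compound 1, with a number 57 percentage points higher from compound 1 to compound 3 (beyond the scatter).

Compound 4 is `Nc1ccccc1NC(=O)c1ccc(CNc2nc(Cl)nc3c2ncn3Cc2ccccc2)cc1`, not yet measured in this assay. It differs from compound 3 in one place: benzyl in place of isopropyl on an aromatic nitrogen. Among the measured compounds shown here, the one measured step that bears on this place is the change of the same group on the same aromatic nitrogen, a number 57 percentage points higher from compound 1 to compound 3 (beyond the scatter), which is large. Butyl sits low and isopropyl high; benzyl has been measured at this place in no compound here, so the direction rests on a single step and is uncertain. A step below the scatter is as plausible as a drop toward the number of compound 1.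

Compound 4 is therefore estimated at 35%, within 8% to 70%, the expected step being a number 28.8 percentage points lower from compound 3 to compound 4 (beyond the scatter).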

Compound 4, a percentage reported as inhibition, at one concentration (the size of the read-out at that concentration, not a potency): 5.01%
Beside the measured number, compound 4's estimate is 30 percentage points above it; measured number outside the range, below it.
By their numbers in this assay, from the lowest: compounds 4, 1 and 2 (each within the scatter of the next); then compound 3.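

In this assay, benzyl in place of isopropyl on the aromatic nitrogen gives a number 58.8 percentage points lower from compound 3 to compound 4 (beyond the scatter) and so removes almost all of the effect that compound 3 shows. The earlier butyl step is therefore no isolated case: two different groups at this place, one an open chain and one carrying a six-membered aromatic ring of carbon only, both fall far from isopropyl, while phenyl in place of propyl on the saturated chain carbon bound to the aromatic nitrogen gives a number 1.8 percentage points lower from compound 1 to compound 4 (within the scatter) and does not separate compound 1 from compound 4. Among the three groups compared on this nitrogen, isopropyl alone stands apart, and no measurement shown bears on why the number depends on the group at this place.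

On these data alone, whether the high number belongs to isopropyl alone stays open, since a shorter chain such as ethyl or a small ring such as cyclopropyl on the same nitrogen would test how narrow this requirement is. As far as these compounds go, it also stays open whether a benzyl group carrying an amine or a carboxylic acid, or a longer chain ending in a hydroxyl group, could bring the number back on the shared core.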